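The source may hold more compounds than are shown below. What is called first, only, known or untested is meant among the compounds shown, and "the series" means these compounds.

Measured compounds and their values:

Compound 1 `Nc1ncc(-c2ccccc2)c(-c2ccccc2)n1`: 32%
Compound 2 `COc1ccc(-c2cnc(N)nc2-c2ccccc2)cc1`: 56%
Compound 3 `Nc1ncc(-c2ccncc2)c(-c2ccccc2)n1`: > 80%

Of the compounds shown here, three sharing one core have been tested in an assay on CHO cells for displacement of a labelled ligand from adenosine receptor A1 (Homo sapiens), read by scintillation counting, with a stated time of 1 h, tested at 1 uM; on this read-out higher numbers stand for more inhibition at the one concentration tested (going by the name of the read-out) and lower numbers for less inhibition. Compound 1 gives 32%, the lowest of the two plain numbers. Compound 2 gives 56%, and the step of a number 24 percentage points higher from compound 1 to compound 2 (beyond the scatter) comes from a methoxy in place of hydrogen on an aromatic carbon. Compound 3 reaches the assay limit (the limit of > 80% in this assay, at which 1 of the 3 values shown sits), so its value is a limit rather than a number. The step of a number at least 48 percentage points higher from compound 1 to compound 3 (beyond the scatter) comes from pyridin-4-yl in place of phenyl on an aromatic carbon.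

Compound 4 `Nc1ncc(-c2ccccc2)c(-c2ccco2)n1` is not yet measured. It differs from compound 1 as follows: furan-2-yl in place of phenyl on an aromatic carbon

The step from compound 1 to compound 3 is the closer parallel, since it also puts a heteroaromatic ring in place of phenyl, though on another aromatic carbon of the core; that step was large. Because of a number at least 48 percentage points higher from compound 1 to compound 3 (beyond the scatter) a rise beyond the scatter is expected for compound 4, though a smaller one, since the change sits on a different carbon and a five-membered ring enters. Compound 4 is therefore expected to give 48%, between 20% and 76%, meaning an expected step of a number 16 percentage points higher from compound 1 to compound 4 (beyond the scatter).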

Compound 4, a percentage reported as inhibition, at one concentration (the size of the read-out at that concentration, not a potency): 26%
Beside the measured number, compound 4's estimate is 22 percentage points above it; low and high end bracket the measured number.
By their numbers in this assay, from the lowest: compounds 4 and 1 (each within the scatter of the next); then compound 2. At a limit, above all of these: compound 3.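

In this assay, the phenyl on the carbon next to the ring nitrogen can be replaced by furan-2-yl with no readable difference: the result is a number 6 percentage points lower from compound 1 to compound 4 (within the scatter). At this position, then, a five-membered aromatic ring with one oxygen serves about as well as phenyl, and the large step seen with pyridin-4-yl on another aromatic carbon of the core does not carry over to this heteroaromatic swap on this carbon. None of the measurements shown gives a reason for this difference between the two positions.

Going by these compounds, it remains open whether a thiophene ring, with sulfur in place of the furan oxygen, or pyridin-4-yl would read the same on this carbon. On these data alone, it is also open what a group without a ring, such as an amine or a short carbon chain, would do here.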